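From compound 3 to compound 4: an untested change

The compounds below may be only part of what the source reports. "The series", "measured", "known", "first", "only" and "open" are said of these compounds alone.

In a functional assay on HepG2 cells (Homo sapiens) for inhibition, read by MTT assay, with a stated time of 48 h (on this read-out lower numbers stand for stronger inhibition and higher numbers for weaker inhibition), compound 1 `COc1ccc(N(C)c2nc(C)nc3ccccc23)cc1C(=O)OCC[Se]C#N` gives 890 nM, compound 2 `COc1ccc(N(C)c2nc(C)nc3ccccc23)cc1C(=O)OCCC[Se]C#N` gives 340 nM and compound 3 `COc1ccc(N(C)c2nc(C)nc3ccccc23)cc1C(=O)OCCCC[Se]C#N` gives 975 nM. Compound 3 therefore stands level with compound 1, as the result is a 1.1-fold higher number from compound 1 to compound 3 (0.04 log units; within the scatter). Only compound 2 stands apart, with a 2.6-fold lower number from compound 1 to compound 2 (0.42 log units; beyond the scatter) and a 2.9-fold higher number from compound 2 to compound 3 (0.46 log units; beyond the scatter).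

Compound 4 `COc1ccc(N(C)c2nc(C)nc3ccccc23)cc1OCCCC[Se]C#N` carries a different change: a group of 8 heavy atoms (5 carbon, 1 nitrogen, 1 oxygen, 1 selenium; no ring) in place of a group of 10 heavy atoms (6 carbon, 1 nitrogen, 2 oxygen, 1 selenium; no ring), on an aromatic carbon, ortho to a methoxy group. Within the data shown here, no measured step touches this change, since the three measured compounds differ only in the length of their saturated chain. Those steps can only hint at how far numbers move in this small set, and the largest is a 2.9-fold higher number from compound 2 to compound 3 (0.46 log units; beyond the scatter). They give no direction, so the direction here is a tentative guess. The expected result is a 2.2-fold lower number from compound 3 to compound 4 (0.34 log units; beyond the scatter), a step of similar modest size. For compound 4 the estimated value in this assay is 450 nM, with an expected range from 110 nM to 1800 nM.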

Compound 4, half-maximal inhibitory concentration: 6460 nM
The estimate for compound 4 lay 14-fold (1.16 log units) below the measured number; measured number outside the range, above it.
By their numbers in this assay, from the lowest: compound 2; then compounds 1 and 3 (each within the scatter of the next); then compound 4.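

In this assay, taking the carbonyl out of the link on this aromatic carbon, with the rest of the chain of compound 3 left in place, gives a 6.6-fold higher number from compound 3 to compound 4 (0.82 log units; beyond the scatter), a bigger step than any that chain length alone produced among the three esters. The steps from the two shorter esters point the same way, with a 7.3-fold higher number from compound 1 to compound 4 (0.86 log units; beyond the scatter) and a 19-fold higher number from compound 2 to compound 4 (1.28 log units; beyond the scatter), although each of these also changes the chain, and compound 4 ends up as the weakest of the four in this read-out. Nothing available explains why removing the carbonyl costs so much.

Among these compounds, only one chain length appears without the carbonyl, so it remains open whether a shorter chain would give the same optimum there as among the esters. An amide link on this aromatic carbon, in place of the ester, also remains an open case.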